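Trimming the ether chain back to a free hydroxyl

The source may report more compounds than this note shows. Statements on the series, on what has been measured and on what is new or still open speak of the compounds shown alone.

Compound 1 `CO[C@H]1CC=C2CCN(C)[C@H]2C1` gives 3400 nM in an assay on HEK293 cells for displacement of a labelled ligand from Neuronal acetylcholine receptor; alpha4/beta2 (Rattus norvegicus), with a stated time of 4 h; a higher number here means a weaker inhibitor, a lower number a stronger inhibitor. Compound 2 `CCO[C@H]1CC=C2CCN(C)[C@H]2C1` gives 300000 nM in this assay, and the step of an 88-fold higher number from compound 1 to compound 2 (1.95 log units; beyond the scatter) is large. Compound 3 `COCCO[C@H]1CC=C2CCN(C)[C@H]2C1` is reported in this assay only as a limit, > 300000 nM, which is the limit of the assay at which one of the three values sits (the limit of > 300000 nM in this assay, at which 1 of the 3 values shown sits). The step of an at least 88-fold higher number from compound 1 to compound 3 (1.94 log units; beyond the scatter) is therefore also large, and the step of a number no lower from compound 2 to compound 3 (the limit leaves the size open) cannot be sized.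

Compound 4 `CN1CCC2=CC[C@H](O)C[C@@H]21` has not yet been measured. It differs from compound 3 by hydrogen in place of 2-methoxyethyl on an oxygen on a saturated carbon, which is the same difference as 2-methoxyethoxy to hydroxy. The steps from compound 1 to compound 2 and to compound 3 show that growing the group on this oxygen costs a great deal; the change to compound 4 runs the other way, cutting the group off entirely, so a large step toward a lower number is expected in this assay. Whether the free hydroxyl lands near compound 1 or somewhat off it cannot be read from the three values. Compound 4 is therefore estimated at 5000 nM in this assay, within 800 nM to 40000 nM, an expected step of an at least 60-fold lower number from compound 3 to compound 4 (1.77 log units; beyond the scatter).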

Compound 4, inhibition constant: 300000 nM
Compound 4: middle estimate off by 60-fold (1.78 log units), on the low side; measured number outside the range, above it.
By their numbers in this assay, from the lowest: compound 1; then compounds 2 and 4 (each within the scatter of the next).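

Taking the group off this oxygen altogether leaves the free hydroxyl of compound 4 and the ethyl ether of compound 2 impossible to tell apart in this assay: hydrogen in place of ethyl gives no change at the digits printed from compound 2 to compound 4 (within the scatter). Hydrogen in place of methyl gives an 88-fold higher number from compound 1 to compound 4 (1.95 log units; beyond the scatter), so the earlier picture, in which only growing the group from methyl cost binding, gives way to one in which the lower number of compound 1 is lost both on lengthening the group to ethyl and on removing it. Hydrogen in place of 2-methoxyethyl gives a number no higher from compound 3 to compound 4 (the limit leaves the size open). Compound 3 stands only as a limit, and the steps that touch it and have no sized value cannot be read: the limit of > 300000 nM in this assay, at which 1 of the 4 values shown sits.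

Going by these compounds, whether another small group on this oxygen, such as an acetyl or a trifluoromethyl, could match or go below compound 1 remains open. Also open, on these data alone, is whether an amine in place of the ether oxygen, carrying the same methyl, would keep the number of compound 1.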